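Moving to 3-chlorophenyl: one change, one open number

The compounds below may be only part of what the source reports. "The series", "measured", "known", "first", "only" and "open" are said of these compounds alone.

In an ADME assay on THP-1 cells (Homo sapiens) for inhibition, read by MTT assay, with a stated time of 48 h (on this read-out lower numbers stand for stronger inhibition of growth and higher numbers for weaker inhibition of growth), compound 3 (`Clc1ccc(Cn2cc(COc3ccc(Cl)cc3)nn2)cc1`) gives 17.4 ug/mL and stands within the scatter of compound 2 (`O=[N+]([O-])c1cccc(Cn2cc(COc3ccc(Cl)cc3)nn2)c1`) at 34.9 ug/mL on this read-out. Compound 1 (`Cc1ccc(OCc2cn(Cc3cccc(Cl)c3)nn2)cc1`) gives 36.7 ug/mL as a higher number than compound 3, and that gap lies beyond the scatter.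

Compound 4 (`Clc1ccc(OCc2cn(Cc3cccc(Cl)c3)nn2)cc1`) has not yet been measured. It differs from compound 3 in one group, with 3-chlorophenyl in place of 4-chlorophenyl on a saturated chain carbon bound to an aromatic nitrogen and the same atoms joined differently. Within the data shown here, no measured pair shows a single change, so no direct step is available as a guide. The expectation therefore rests on the narrow span of the three values, with compound 3 at 17.4 ug/mL and compound 1 at 36.7 ug/mL as its ends. In this assay the estimate is a 1.5-fold higher number from compound 3 to compound 4 (0.17 log units; within the scatter) as an expected move toward a higher number that stays within the scatter. In this assay compound 4 is expected at 26 ug/mL with a range from 14 ug/mL to 46 ug/mL as the estimated span.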

Compound 4, concentration for 50% growth inhibition in the THP-1 assay: 20.9 ug/mL
The estimate for compound 4 lay 1.2-fold (0.09 log units) above the measured number; the range from low to high includes it.
By their numbers in the THP-1 assay, from the lowest: compounds 3, 4, 2 and 1 (each within the scatter of the next, the first and the last beyond it).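

In the THP-1 assay compound 3 gives 17.4 ug/mL and compound 4 gives 20.9 ug/mL, and the first single change read at this position, 3-chlorophenyl in place of 4-chlorophenyl on a saturated chain carbon bound to an aromatic nitrogen, appears as a 1.2-fold higher number from compound 3 to compound 4 (0.08 log units; within the scatter). In a physicochemical assay, read by spectrophotometry, with a stated time of 30 min (on this read-out lower numbers stand for stronger inhibition and higher numbers for weaker inhibition), compound 3 gives 26.1 ug/mL and compound 4 gives 23.3 ug/mL, and the same change appears as a 1.1-fold lower number from compound 3 to compound 4 (0.05 log units; within the scatter), so neither read-out separates the two chlorophenyl groups at this place. Among these compounds, compound 4 also gives the first direct readings at an aromatic carbon of the other ring, where the THP-1 assay shows a 1.7-fold lower number from compound 2 to compound 4 (0.22 log units; within the scatter) for chloro in place of nitro and a 1.8-fold lower number from compound 1 to compound 4 (0.24 log units; within the scatter) for chloro in place of methyl and both steps stay within the scatter. No evidence is at hand on what lies behind these steps.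

On these data alone, whether any group at these places moves the number beyond the scatter remains open. A methoxy group or an amine in place of the chloro could answer that, and so could a longer chain in place of the saturated chain carbon.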